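A few compounds are considered here, and "the series" means these few. Any claim that something is new, unique, unknown or untested is made for them only; others in the source may bear on it.

Measured in an assay on CHO cells for displacement of a labelled ligand from adenosine receptor A3 (Homo sapiens); on this read-out higher numbers stand for weaker inhibition and lower numbers for stronger inhibition:
compound 1 `O=C(NC1CC1)[C@H]1O[C@@H](n2cnc3c(NCc4cccc(I)c4)nc(Cl)nc32)[C@H](O)[C@@H]1O` — 2.95 nM
compound 2 `O=C([C@H]1O[C@@H](n2cnc3c(NCc4cccc(I)c4)nc(Cl)nc32)[C@H](O)[C@@H]1O)N1CCOCC1` — 513 nM

Compound 1 stands lowest of the two numbers; the nearest, compound 2, lies a large step higher. Compound 3 `Cc1ccccc1CNc1nc(Cl)nc2c1ncn2[C@@H]1O[C@H](C(=O)NC2CC2)[C@@H](O)[C@H]1O` differs from compound 1 by 2-methylphenyl in place of 3-iodophenyl on a saturated chain carbon bound to a nitrogen on an aromatic ring. Among the compounds with values here, the only measured step, a 170-fold higher number from compound 1 to compound 2 (2.24 log units; beyond the scatter), changes the group on the carbonyl carbon and not the benzyl group, so no measured step bears on this change. Without a guide from the series, a moderate weakening beyond the scatter is expected, a 10-fold higher number from compound 1 to compound 3 (1.01 log units; beyond the scatter). For compound 3 the estimate in this assay is 30 nM, with a range from 6 nM to 150 nM.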

Compound 3, inhibition constant: 27.5 nM
Compound 3: middle estimate off by 1.1-fold (0.04 log units), on the high side; the range from low to high includes it.
By their numbers in this assay, from the lowest: compound 1; then compound 3; then compound 2.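

The (3-iodobenzyl)amino group had not been varied before. In this assay, changing it to (2-methylbenzyl)amino gives a 9.3-fold higher number from compound 1 to compound 3 (0.97 log units; beyond the scatter), so the series responds to this group as well as to the group on the carbonyl carbon, and compound 3 still reads 27.5 nM. No evidence is available to explain this step.

As far as these compounds go, the substituent and its place on the phenyl ring change together, so their contributions cannot be separated. 3-Methylphenyl or 2-iodophenyl would separate them, and an aminophenyl or a longer chain in place of benzyl remains open.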